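The source may hold more compounds than are shown below. What is called first, only, known or untested is meant among the compounds shown, and "the series" means these compounds.

Compound 1 `C[Se]/C(=N\C(=O)c1cc2ccccc2s1)NC(=O)c1cc2ccccc2s1`: 94000 nM
Compound 2 `C[Se]/C(=N\C(=O)c1sccc1Cl)NC(=O)c1sccc1Cl`: > 100000 nM

For the measured compounds named here, in a functional assay on PC-3 cells (Homo sapiens) for cytotoxicity, read by MTT assay, with a stated time of 72 h (a lower number here means that less compound is tolerated, a higher number that more compound is tolerated), compound 1 gives 94000 nM and stands as the only plain number among the two measured compounds. Compound 2 reaches only (the limit of > 100000 nM in this assay, at which 1 of the 2 values shown sits), a limit of this assay rather than a measured number. Compound 3 `O=C(/N=C(/NC(=O)c1cc2ccccc2s1)[Se]Cc1ccccc1)c1cc2ccccc2s1` has not been tested; it differs from compound 1 by phenyl in place of hydrogen on a saturated chain carbon bound to a selenium atom. Going by the values given here, no step between two measured compounds is available to show how a change at this position moves the read-out, so the expected step is small: a modest shift toward a lower number, close to the usual scatter. Compound 3 is therefore expected to give 60000 nM in this assay, with a range from 20000 nM to 150000 nM. The estimated step of a 1.6-fold lower number from compound 1 to compound 3 (0.19 log units; within the scatter) expresses this expectation, and whether it holds becomes known once compound 3 is measured.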

Compound 3, concentration lethal to 50% of the cells: 86300 nM
For compound 3 the middle estimate is 1.4-fold (0.16 log units) below the measured one, within the range that was stated.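

For the compounds shown here, with phenyl in place of hydrogen on a saturated chain carbon bound to a selenium atom, this assay gives the first step that can be read at this position (a 1.1-fold lower number from compound 1 to compound 3 (0.04 log units; within the scatter)). The position therefore accepts the move from methyl to benzyl with the read-out staying within the scatter, so on this core the two groups cannot be told apart in this assay. Nothing among the values shown offers a reason for this outcome.

From the compounds shown here alone, it remains open whether an amine, a carboxylic acid or a longer chain at this position would also stay within the scatter. Going by these compounds, it also remains open whether the move from methyl to benzyl would read the same way on a core other than that of compound 1.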